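Iodo removal on the shared core: BJ cell antiproliferative assay

A few compounds are considered here, and "the series" means these few. Any claim that something is new, unique, unknown or untested is made for them only; others in the source may bear on it.

Compound 1 `COc1ccc(-c2c(I)c(=O)c3c(OC)cc(OC)cc3n2S(=O)(=O)c2ccc(OC)cc2)cc1` is the reference point. In an ADME assay on BJ cells (Homo sapiens) for antiproliferative activity, with a stated time of 72 h (a higher number here means that more compound is needed for the effect, a lower number that less compound is needed), compound 1 gives only a limit, > 34400 nM. Among the compounds with values here, the other two members measured so far also sit at limits. Compound 2 `COC(=O)c1cc(=O)c2c(OC)cc(OC)cc2[nH]1` gives a limit of > 34400 nM in this assay. Compound 3 `COc1ccc(-c2cc(=O)c3c(OC)cc(OC)cc3n2S(=O)(=O)c2ccc(F)cc2)cc1` gives a limit of > 65500 nM in this assay. Two of the three values sit at the limit described by the limit of > 34400 nM in this assay, at which 2 of the 3 values shown sit, and one at the limit described by the limit of > 65500 nM in this assay, at which 1 of the 3 values shown sits. With nothing but limits shown, no ordering among compound 1, compound 2 and compound 3 can be drawn from these numbers.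

Compound 4 `COc1ccc(-c2cc(=O)c3c(OC)cc(OC)cc3n2S(=O)(=O)c2ccc(OC)cc2)cc1` is not yet measured. It differs from compound 1 by hydrogen in place of iodo on an aromatic carbon. Within the data shown here, no measured pair in this assay differs by a single change, so no step size is known from data. Given that compound 1 and compound 3 both return limits, no shift beyond the scatter is expected here; the expected step that the limit leaves unreadable from compound 1 to compound 4 is essentially nil. Compound 4 is therefore estimated at 60000 nM in this assay, within a range of 20000 nM to 200000 nM, most likely reported again as a limit.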

Compound 4, half-maximal effective concentration: > 82700 nM
Compound 4 ended at the assay's limit; the forecaster's own chance of this, stated with the estimate: 85%; middle value at least 1.3-fold (0.13 log units) from the limit.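

Compound 4 returns only a limit in this assay, as do compound 1 and compound 3, so neither the step from compound 1 to compound 4 nor that from compound 3 to compound 4 can be read. The compounds shown leave open whether any member reaches a readable value in this assay.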